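Swapping Formyl for (Methoxymethoxy)methyl on the Shared Core

The compounds below may be only part of what the source reports. "The series", "measured", "known", "first", "only" and "open" are said of these compounds alone.

compound 1 `COC(=O)c1ccc(-c2cnc(C(=O)CCCCCCc3ccccc3)o2)nc1`: 3.1 nM
compound 2 `O=Cc1ccc(-c2cnc(C(=O)CCCCCCc3ccccc3)o2)nc1`: 2.2 nM

In an assay for inhibition of Fatty-acid amide hydrolase 1 (Rattus norvegicus), using a Dixon plot (on this read-out higher numbers stand for weaker inhibition and lower numbers for stronger inhibition), compound 2 stands lowest of the two numbers, with compound 1 nearest; the step of a 1.4-fold lower number from compound 1 to compound 2 (0.15 log units; within the scatter) lies within the scatter. Compound 3 `COCOCc1ccc(-c2cnc(C(=O)CCCCCCc3ccccc3)o2)nc1` differs from compound 2 by (methoxymethoxy)methyl in place of formyl on an aromatic carbon. Among the compounds with values here, the only measured step bearing on this carbon is the one from compound 1 to compound 2, and it was small, so small changes there appear tolerated; the entering group, however, is larger than either group measured. A modest move toward a higher number is therefore expected, a 2.7-fold higher number from compound 2 to compound 3 (0.44 log units; beyond the scatter). Compound 3 is estimated at 6 nM, with a range from 1.5 nM to 25 nM.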

Compound 3, inhibition constant: 10.1 nM
For compound 3 the middle estimate is 1.7-fold (0.23 log units) below the measured one; the range from low to high includes it.
By their numbers in this assay, from the lowest: compounds 2 and 1 (each within the scatter of the next); then compound 3.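

In this assay, the position on the aromatic carbon para to a large group now shows a change beyond the scatter: (methoxymethoxy)methyl gives a 4.6-fold higher number from compound 2 to compound 3 (0.66 log units; beyond the scatter) and a 3.3-fold higher number from compound 1 to compound 3 (0.51 log units; beyond the scatter). Both steps are modest, so this replacement is tolerated only in part, unlike the earlier exchange between the two carbonyl groups. Nothing available here accounts for the size of these steps.

The compounds shown leave open whether a hydroxymethyl group, a plain methyl or a carboxylic acid on this carbon would stay close to compound 2 or move further away.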